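The source may report more compounds than this note shows. Statements on the series, on what has been measured and on what is new or still open speak of the compounds shown alone.

Measured so far in a functional assay on A-375 cells (Homo sapiens) for antiproliferative activity, read by CCK-8 assay, with a stated time of 72 h, tested at 2 uM; on this read-out higher numbers stand for a stronger effect at the one concentration tested and lower numbers for a weaker effect:

- Compound 1 `Nc1ccccc1NC(=O)c1ccc(CSC(=S)N2CCN(C(c3ccccc3)c3ccccc3)CC2)cc1` gives 8.7%
- Compound 2 `COc1ccc(N2CCN(C(=S)SCc3ccc(C(=O)Nc4ccccc4N)cc3)CC2)cc1` gives 28.1%
- Compound 3 `CC1CCN(C(=S)SCc2ccc(C(=O)Nc3ccccc3N)cc2)CC1` gives 32.7%

All three share the same core and differ only in the group attached to the amine nitrogen of the six-membered ring. Compound 2 stands second highest of the three numbers. Its nearest neighbour is compound 3, whose value lies within the usual scatter of this kind of measurement, so the two cannot be told apart on these data. Its furthest neighbour is compound 1, whose value lies well below, beyond the scatter.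

Compound 4 `Nc1ccccc1NC(=O)c1ccc(CSC(=S)N2CCN(c3ccccc3F)CC2)cc1` has not yet been measured. Compared with compound 2 the change is 2-fluorophenyl in place of 4-methoxyphenyl on an amine nitrogen in a ring. Among the measured compounds shown here, no pair of measured compounds differing in exactly this way is available, so there is no measured step to lean on. The two compounds bearing a single aromatic ring on that nitrogen, compound 2 and compound 3, sit close together, while compound 1 with its larger group sits lower. On that basis the step from compound 2 to compound 4 is expected to be small, with a slight lean downward, and most likely not beyond the scatter: a number 4.1 percentage points lower from compound 2 to compound 4 (within the scatter). Compound 4 is therefore estimated at 24% in this assay, within a range from 8% to 42%.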

Compound 4, a percentage reported as inhibition, at one concentration (the size of the read-out at that concentration, not a potency): 18.7%
Beside the measured number, compound 4's estimate is 5.3 percentage points above it; the range from low to high includes it.
By their numbers in this assay, from the lowest: compounds 1, 4, 2 and 3 (each within the scatter of the next, the first and the last beyond it).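

In this assay, among the compounds shown here, this is the first measured step at this position, and it reads a number 9.4 percentage points lower from compound 2 to compound 4 (within the scatter), so 2-fluorophenyl in place of 4-methoxyphenyl on the amine nitrogen leaves the two compounds indistinguishable at the one concentration tested. The swap is larger than it may look on paper: the group that leaves counts 1 hydrogen-bond acceptor and the group that enters counts 0, and both the substituent and its numbered place on the aromatic ring differ, so this single step alters several features together and separates none of them. No measurement in hand bears on the reason behind this result.

The compounds shown include no plain phenyl, 4-fluorophenyl or 2-methoxyphenyl, the groups that would tell the effect of the substituent apart from that of its place on the aromatic ring. Going by these compounds, it also stays open whether a more different group on this nitrogen, such as an aminophenyl or a carboxylic acid on the phenyl, would give a step beyond the scatter.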